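Swapping Methyl for Bromo on the Benzyl Ring

The compounds below may be only part of what the source reports. "The series", "measured", "known", "first", "only" and "open" are said of these compounds alone.

Of the compounds shown here, three that share one core have been tested in a functional assay on HCT-116 cells (Homo sapiens) for antiproliferative activity, read by MTT assay, with a stated time of 48 h; on this read-out lower numbers stand for stronger inhibition and higher numbers for weaker inhibition. Compound 1 `COc1cc(N(Cc2ccccc2)C(=O)CSc2nc3ccccc3s2)cc(OC)c1OC` gives 54500 nM. Compound 2 `COc1ccc(CN(C(=O)CSc2nc3ccccc3s2)c2cc(OC)c(OC)c(OC)c2)cc1C` gives 17100 nM, and the change between them is a 3.2-fold lower number from compound 1 to compound 2 (0.50 log units; beyond the scatter). Compound 3 `COc1cc(N(Cc2ccc(C)cc2)C(=O)CSc2nc3ccccc3s2)cc(OC)c1OC` returns only a limit of the assay, > 80000 nM, so its true number is not known. That limit places compound 3 at the limit of > 80000 nM in this assay, at which 1 of the 3 values shown sits. The step of an at least 1.4-fold higher number from compound 1 to compound 3 (0.16 log units; that floor lies within the scatter) and the step of an at least 4.6-fold higher number from compound 2 to compound 3 (0.67 log units; beyond the scatter) show that compound 3 stands no better than either neighbour in this assay.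

Compound 4 `COc1cc(N(Cc2ccc(Br)cc2)C(=O)CSc2nc3ccccc3s2)cc(OC)c1OC` differs from compound 3 in one place: bromo in place of methyl on an aromatic carbon, so that 4-methylphenyl becomes 4-bromophenyl. Going by the values given here, no measured step involves bromo, and the steps on this ring ran in both directions, so the data give no clear direction for this swap. The expected step is therefore an at least 1.3-fold lower number from compound 3 to compound 4 (0.12 log units; that floor lies within the scatter), within the scatter. Compound 4 is estimated at 60000 nM, with a range from 25000 nM to 150000 nM, and a real chance that this assay again reports only a limit.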

Compound 4, half-maximal inhibitory concentration: 63800 nM
Compound 4: the middle estimate sits 1.1-fold (0.03 log units) below what was measured; measured number inside the range.
By their numbers in this assay, from the lowest: compound 2; then compounds 1 and 4 (each within the scatter of the next). At a limit, above all of these: compound 3.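

With bromo on this ring, compound 4 gives a measured number in this assay, whereas compound 3 gives only a limit: the limit of > 80000 nM in this assay, at which 1 of the 4 values shown sits. Going by these compounds, the swap of methyl for bromo can therefore be read only as a floor, an at least 1.2-fold lower number from compound 3 to compound 4 (0.09 log units; that floor lies within the scatter), and its true size stays unknown. Bromo in place of hydrogen cannot be told apart from the scatter, a 1.2-fold higher number from compound 1 to compound 4 (0.07 log units; within the scatter), while the 4-methoxy-3-methylphenyl group of compound 2 keeps a clear edge over 4-bromophenyl, a 3.7-fold higher number from compound 2 to compound 4 (0.57 log units; beyond the scatter).

Compound 2 carries both a methoxy and a methyl on this ring, so the compounds shown do not tell which of the two goes with its lower number. Also open, on these data alone, is how an amine or a carboxylic acid in place of bromo would read in this assay.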